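Ethoxycarbonyl in Place of Nitro: Expected Cytotoxicity of Compound 4

This account rests on a few compounds, and the source may have more. Where it says the series, first, only, none or still open, it means among the compounds named here.

In a toxicity assay on MT4 cells (Homo sapiens) for cytotoxicity, read by MTT assay, with a stated time of 5 days (a lower number here means that less compound is tolerated, a higher number that more compound is tolerated), three compounds that share one core have been measured. Compound 1 `CCOC(=O)c1ccc(NC(=O)CSc2nnc(COc3cc(C)ccc3C(C)C)n2Cc2ccccc2)cc1` gives 19.8 ug/mL, compound 2 `CC(=O)Nc1ccc(OCc2nnc(SCC(=O)Nc3ccc(Cl)cc3)n2Cc2ccccc2)cc1` gives 14 ug/mL, and compound 3 `CC(=O)Nc1ccc(OCc2nnc(SCC(=O)Nc3ccc([N+](=O)[O-])cc3)n2Cc2ccccc2)cc1` gives 105 ug/mL, which is the highest of the three numbers. For the measured compounds named here, the only single-point step among them, a 7.5-fold higher number from compound 2 to compound 3 (0.88 log units; beyond the scatter), shows that the nitro-bearing compound 3 is tolerated at a higher concentration than its chloro counterpart. Compound 4 `CCOC(=O)c1ccc(NC(=O)CSc2nnc(COc3ccc(NC(C)=O)cc3)n2Cc2ccccc2)cc1` differs from compound 3 by ethoxycarbonyl in place of nitro on an aromatic carbon. Going by the values given here, no measured step isolates this change, but compound 1 carries the same ethoxycarbonyl anilide with a different aryl ether and sits well below compound 3 in this assay. The nitro group thus appears tied to the high number of compound 3, and its removal is expected to bring the value back toward the range of compound 1 and compound 2. Compound 4 is therefore estimated at 30 ug/mL, within 12 ug/mL to 80 ug/mL, an expected step of a 3.5-fold lower number from compound 3 to compound 4 (0.54 log units; beyond the scatter).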

Compound 4, half-maximal cytotoxic concentration: 91.1 ug/mL
Estimate against measurement, compound 4: 3.0-fold (0.48 log units) below; the whole stated range lies below it.
By their numbers in this assay, from the lowest: compounds 2 and 1 (each within the scatter of the next); then compounds 4 and 3 (each within the scatter of the next).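

Exchanging nitro for ethoxycarbonyl on this aromatic carbon, para to a large group, gives a 1.2-fold lower number from compound 3 to compound 4 (0.06 log units; within the scatter) in this assay, so the high number of compound 3 does not depend on nitro alone. Chloro is what stands apart at this position so far, with a 6.5-fold higher number from compound 2 to compound 4 (0.81 log units; beyond the scatter) in the same direction as a 7.5-fold higher number from compound 2 to compound 3 (0.88 log units; beyond the scatter). With ethoxycarbonyl held in place, the other end of the molecule also moves the number, as 4-acetamidophenyl in place of 2-isopropyl-5-methylphenyl gives a 4.6-fold higher number from compound 1 to compound 4 (0.66 log units; beyond the scatter).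

On these data alone, whether an amine or a carboxylic acid on this aromatic carbon would stay with compound 3 and compound 4 or fall toward compound 2 remains open. Nothing available explains the differences among these groups.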